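Replacing a cyclopropylamino group with a pyridinyl piperazine

The source may report more compounds than this note shows. Statements on the series, on what has been measured and on what is new or still open speak of the compounds shown alone.

Compound 1 `O=C(Nc1ccccc1)Nc1nc(Sc2c[nH]c3ccccc23)cc(N2CCN(c3ccccn3)CC2)n1`: 19500 nM
Compound 2 `Cc1cc(Cl)ccc1NC(=O)Nc1nc(Sc2c[nH]c3ccccc23)cc(N2CCCC2)n1`: 9440 nM
Compound 3 `Cc1cc(Cl)ccc1NC(=O)Nc1nc(NC2CC2)cc(Sc2c[nH]c3ccccc23)n1`: 14600 nM

In a functional assay on MDA-MB-231 cells (Homo sapiens) for inhibition, with a stated time of 72 h (a lower number here means a stronger inhibitor, a higher number a weaker inhibitor), compound 3 gives 14600 nM, which stands close to compound 1 and compound 2, all within the scatter of one another. Compound 4 `Cc1cc(Cl)ccc1NC(=O)Nc1nc(Sc2c[nH]c3ccccc23)cc(N2CCN(c3ccccn3)CC2)n1` arises from compound 3 by the change (4-(pyridin-2-yl)piperazin-1-yl in place of cyclopropylamino on an aromatic carbon). Among the measured compounds shown here, the only measured step at this position, a 1.5-fold higher number from compound 2 to compound 3 (0.19 log units; within the scatter), stayed within the scatter. Compound 1 carries the same entering group with a different urea substituent and gives 19500 nM, again close to compound 3. No step beyond the scatter is therefore expected, and compound 4 is estimated at 15000 nM (range 6000 nM to 40000 nM), meaning an expected step of a 1.0-fold higher number from compound 3 to compound 4 (0.01 log units; within the scatter).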

Compound 4, half-maximal inhibitory concentration: 34700 nM
Compound 4: middle estimate off by 2.3-fold (0.36 log units), on the low side, within the range that was stated.
By their numbers in this assay, from the lowest: compounds 2, 3, 1 and 4 (each within the scatter of the next, the first and the last beyond it).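

In this assay, this position does respond to the group placed on it: 4-(pyridin-2-yl)piperazin-1-yl gives steps beyond the scatter against both cyclopropylamino (a 2.4-fold higher number from compound 3 to compound 4 (0.38 log units; beyond the scatter)) and pyrrolidin-1-yl (a 3.7-fold higher number from compound 2 to compound 4 (0.57 log units; beyond the scatter)), towards a weaker inhibitor. From the compounds shown here alone, with this group in place, 4-chloro-2-methylphenyl instead of phenyl on the urea stays within the scatter (a 1.8-fold higher number from compound 1 to compound 4 (0.25 log units; within the scatter)). (No evidence on hand bears on this result) Still open is whether the piperazine ring or the attached pyridine accounts for the step; morpholine or unsubstituted piperazine at this position would help separate the two.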